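The compounds below may be only part of what the source reports. "The series", "measured", "known", "first", "only" and "open" are said of these compounds alone.

Compound 1, with the structure `O=C(NC1CCS(=O)(=O)CC1)N1CCC(c2nc(-c3ccc4ccccc4n3)no2)CC1`, is measured in a functional assay on Shh Light II cells (Mus musculus) for inhibition, read by a luciferase reporter (on this read-out lower numbers stand for stronger inhibition and higher numbers for weaker inhibition), where compound 1 gives 360 nM. Among the three measured compounds this places compound 1 second highest. Compound 2, `Cn1c(-c2noc(C3CCN(C(=O)NC4CCS(=O)(=O)CC4)CC3)n2)nc2ccccc21`, gives 350 nM, and the change a 1.0-fold lower number from compound 1 to compound 2 (0.01 log units; within the scatter) keeps the two side by side. Compound 3, `O=C(Nc1ncccc1Cl)N1CCC(c2nc(-c3ccc4ccccc4n3)no2)CC1`, gives 2800 nM, a clearly weaker inhibitor.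

Compound 4, `COc1ccccc1OC(=O)N1CCC(c2nc(-c3ccc4ccccc4n3)no2)CC1`, is built from compound 1 by the change (2-methoxyphenoxy in place of (1,1-dioxothian-4-yl)amino on a carbonyl carbon). The group on the carbonyl carbon is swapped, and the hydrogen-bond donor of compound 1 is lost.

Of the measured steps, only one touches the same part of the molecule: from compound 1 to compound 3 the group on the amide-type nitrogen was exchanged, with the result a 7.8-fold higher number from compound 1 to compound 3 (0.89 log units; beyond the scatter). The step from compound 1 to compound 2 alters the aromatic ring at the far end and says nothing about this position. One step is thin evidence, but it points towards weaker inhibition when the (1,1-dioxothian-4-yl)amino group is removed, and the new 2-methoxyphenoxy group differs from it in much the same way as the 3-chloropyridin-2-yl group did.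

Compound 4 is therefore expected to show a step of a 5.0-fold higher number from compound 1 to compound 4 (0.70 log units; beyond the scatter), and its value in this assay is estimated at 1800 nM, with a likely range from 500 nM to 6000 nM.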

Compound 4, half-maximal inhibitory concentration: 250 nM
Compound 4: middle estimate off by 7.2-fold (0.86 log units), on the high side; measured number below the stated range.
By their numbers in this assay, from the lowest: compounds 4, 2 and 1 (each within the scatter of the next); then compound 3.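

In this assay, the step of a 1.4-fold lower number from compound 1 to compound 4 (0.16 log units; within the scatter) shows that this carbonyl carbon can carry 2-methoxyphenoxy in place of (1,1-dioxothian-4-yl)amino with no change beyond the scatter, even though the entering group has an aromatic ring of carbon only and no hydrogen-bond donor; in this pair, neither the 1,1-dioxothian-4-yl ring nor the amide hydrogen of compound 1 is required to keep inhibition at this level. The weaker result for compound 3 can therefore no longer be read as a general penalty for removing (1,1-dioxothian-4-yl)amino: the step of an 11-fold lower number from compound 3 to compound 4 (1.05 log units; beyond the scatter) shows that the outcome depends on which group takes its place, since two replacements that both bring an aromatic ring end up far apart. No supporting evidence is available to explain this gap between the two replacing groups.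

The compounds shown leave open whether the methoxy group or the oxygen joining the ring to the carbonyl carbon matters for this result. A plain phenoxy group and a (2-methoxyphenyl)amino group at the same place would separate those two parts.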